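Swapping Benzyloxy for Phenyl on a Shared Core

The source may report more compounds than this note shows. Statements on the series, on what has been measured and on what is new or still open speak of the compounds shown alone.

Of the compounds shown here, three have so far been tested in an ADME assay on the whole organism (strain CD-1) for metabolic stability, with Mus musculus as the target, at a dose of 50 mg/kg by the oral route; a higher number here means that the compound lasts longer, a lower number that the compound disappears faster. Compound 1 `O=C(N[C@@H]1C[C@@H](C(=O)NC[C@@H]2CC(Br)=NO2)N(C(=O)OCc2cnc3ccccc3c2)C1)c1cccnc1` gives 0.25 h in this assay. Compound 2 `O=C(NC[C@@H]1CC(Br)=NO1)[C@@H]1CCCN1C(=O)OCc1cnc2ccccc2c1` gives 0.25 h. Compound 3 `O=C(NC[C@@H]1CC(Br)=NO1)[C@@H]1C[C@@H](OCc2ccccc2)CN1C(=O)OCc1cnc2ccccc2c1` gives 0.25 h. The steps between them were all flat: no change at the digits printed from compound 1 to compound 2 (within the scatter), no change at the digits printed from compound 1 to compound 3 (within the scatter) and no change at the digits printed from compound 2 to compound 3 (within the scatter). Compound 3 thus stands level with compounds 1 and 2 on the numbers shown.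

Compound 4 `O=C(NC[C@@H]1CC(Br)=NO1)[C@@H]1C[C@@H](c2ccccc2)CN1C(=O)OCc1cnc2ccccc2c1` differs from compound 3 in one place: phenyl in place of benzyloxy on a saturated ring carbon. For the measured compounds named here, no measured step exchanges exactly these two groups. The nearest guide is no change at the digits printed from compound 2 to compound 3 (within the scatter), in which benzyloxy entered at a saturated ring carbon without moving the number, and the other two steps at the same kind of position were equally flat. On that basis the expectation for compound 4 is no step beyond the scatter, which is what no change at the digits printed from compound 3 to compound 4 (within the scatter) means here. Compound 4 is estimated at 0.25 h, with a range from 0.13 h to 0.5 h.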

Compound 4, half-life: 0.25 h
Compound 4: the middle estimate sits on the measured number at the digits printed; the measured number falls inside the stated range.
By their numbers in this assay, from the lowest: compounds 1, 2, 3 and 4 (each within the scatter of the next).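

In this assay, phenyl in place of benzyloxy on this saturated ring carbon removes the oxygen of the group and gives no change at the digits printed from compound 3 to compound 4 (within the scatter). Phenyl in place of hydrogen gives no change at the digits printed from compound 2 to compound 4 (within the scatter), and phenyl in place of ((pyridin-3-yl)carbonyl)amino gives no change at the digits printed from compound 1 to compound 4 (within the scatter), so a directly attached aromatic ring now joins the three earlier groups on this position with no separation among the four compounds. Nothing available accounts for this flat result. 

As far as these compounds go, whether an amine, a carboxylic acid or a longer chain at this same carbon would shift the half-life remains open. Also open, from the compounds shown here alone, is whether a change elsewhere on the shared core would move the number, since these compounds differ only at this position.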